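This account rests on a few compounds, and the source may have more. Where it says the series, first, only, none or still open, it means among the compounds named here.

Two compounds of the series carry a measurement in an ADME assay on microsomes from liver (Homo sapiens) for metabolic stability, tested at 2.5 uM; a lower number here means slower removal, a higher number faster removal of the compound. Compound 1 `O=S(=O)(c1cc(F)cc(F)c1)c1cnc2c(F)cccc2c1-c1cccc(Cl)c1` gives 0.64 mL/min in this assay. Among the compounds with values here, compound 2 `COc1ccc(-c2c(S(=O)(=O)c3cc(F)cc(F)c3)cnc3c(F)cccc23)cc1` gives 2.59 mL/min in this assay and thus holds the higher of the two numbers; the single measured step, a 4.0-fold higher number from compound 1 to compound 2 (0.61 log units; beyond the scatter), separates it from compound 1 and lies beyond the scatter. Compound 3 `COc1ccc(-c2c(S(=O)(=O)c3ccc(F)cc3)cnc3c(F)cccc23)cc1` is not yet measured. It differs from compound 2 in one place: 4-fluorophenyl in place of 3,5-difluorophenyl on a sulfonyl sulfur. Within the data shown here, no measured step touches the group on the sulfonyl sulfur; the only step known, a 4.0-fold higher number from compound 1 to compound 2 (0.61 log units; beyond the scatter), concerns the group on the aromatic carbon and says nothing about the sulfonyl side. Among the measured compounds shown here, with no precedent, the expectation for the step of a 1.0-fold lower number from compound 2 to compound 3 (0.02 log units; within the scatter) is that it stays within the scatter, in no fixed direction. Compound 3 is accordingly estimated at 2.5 mL/min, with a range from 1.2 mL/min to 5 mL/min.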

Compound 3, intrinsic clearance in a liver preparation (reported as CLH), per the amount of preparation that the assay uses: 2.41 mL/min
Compound 3: middle estimate off by 1.0-fold (0.02 log units), on the high side; measured number inside the range.
By their numbers in this assay, from the lowest: compound 1; then compounds 3 and 2 (each within the scatter of the next).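

Within the data shown here, on the sulfonyl sulfur, the first measured step in this assay (a 1.1-fold lower number from compound 2 to compound 3 (0.03 log units; within the scatter)) shows that 4-fluorophenyl and 3,5-difluorophenyl cannot be told apart in this read-out, at least with 4-methoxyphenyl on the aromatic carbon. The only step beyond the scatter remains the one on the aromatic carbon (a 4.0-fold higher number from compound 1 to compound 2 (0.61 log units; beyond the scatter)), so that position, not the sulfonyl side, is so far the only one where the series has shown a measurable difference. No measurement at hand explains the result on the sulfonyl side.

Open, from the compounds shown here alone, is how the number responds when the sulfonyl sulfur carries something other than a fluorinated phenyl, such as a cyclopropyl ring or an aliphatic amine. Also open, going by these compounds, is whether the two fluorinated phenyl groups still read alike with 3-chlorophenyl on the aromatic carbon.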